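A few compounds are considered here, and "the series" means these few. Any claim that something is new, unique, unknown or untested is made for them only; others in the source may bear on it.

Measured so far in a functional assay on BXPC-3 cells (Homo sapiens) for cytotoxicity, read by MTT assay, with a stated time of 72 h; a higher number here means a weaker inhibitor, a lower number a stronger inhibitor:
compound 1 `CCc1ccc(-c2ccc(NC3=CC(=O)c4ncncc4C3=O)cc2)cc1`: 1600 nM
compound 2 `CC1=C(Nc2ccc(N3CCN(C)CC3)cc2)C(=O)c2cncnc2C1=O`: 870 nM

Among the measured compounds shown here, only two compounds have numbers so far. Compound 1 lies within the usual scatter of compound 2, so these two values cannot be told apart and neither compound can be called the better one.

The next compound to follow is compound 3 `O=C1C(Nc2ccc(-c3ccccn3)cc2)=CC(=O)c2ncncc21`. It keeps the core of compound 1 and changes one group: pyridin-2-yl in place of 4-ethylphenyl on an aromatic carbon. That carbon belongs to a six-membered aromatic ring of carbon only, para to a large group.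

For the measured compounds named here, no measured pair shows what this swap does, so any forecast here is rough. The two structures already measured differ in more than one place, yet compound 1 at 1600 nM and compound 2 at 870 nM remain within the scatter of each other. On that thin basis, no step beyond the scatter is expected in this assay, in either direction. The estimated change is a 1.6-fold lower number from compound 1 to compound 3 (0.20 log units; within the scatter). For compound 3 the estimate is 1000 nM, with an expected range of 300 nM to 3000 nM.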

Compound 3, half-maximal inhibitory concentration: 2700 nM
Beside the measured number, compound 3's estimate is 2.7-fold (0.43 log units) below it; low and high end bracket the measured number.
By their numbers in this assay, from the lowest: compounds 2, 1 and 3 (each within the scatter of the next, the first and the last beyond it).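

In this assay, the exchange of 4-ethylphenyl for pyridin-2-yl on this aromatic carbon gives a 1.7-fold higher number from compound 1 to compound 3 (0.23 log units; within the scatter) and so cannot be told apart from no change at all. Among the compounds shown here, this is the first pair that differs in only one place, which gives the first direct reading at this position, para to a large group: a six-membered aromatic ring of carbon only with an ethyl group gave way to a six-membered aromatic ring with 1 hetero atom and 1 hydrogen-bond acceptor, without a step beyond the scatter. No supporting measurement accompanies this step, so the data offer no explanation for it.

Compound 2 differs from compound 1 and compound 3 in more than one place, so its value cannot be read as a step at this position. Still open, as far as these compounds go, is whether a group of a different kind on this carbon, such as a carboxylic acid, a primary amine or a longer alkyl chain on the outer ring, would move the number beyond the scatter, and in which direction.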